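Thiophen-3-yl in Place of Thiophen-2-yl on Compound 3

A few compounds are considered here, and "the series" means these few. Any claim that something is new, unique, unknown or untested is made for them only; others in the source may bear on it.

Compound 3 `Nc1nc2c(c(-c3cccs3)cn2[C@@H]2O[C@H](CO)[C@@H](O)[C@H]2O)c(=O)[nH]1` was tested in a functional assay on HL-60 cells (Homo sapiens) for antiproliferative activity, read by XTT assay, with a stated time of 72 h; a lower number here means a stronger inhibitor, a higher number a weaker inhibitor. In this assay compound 3 reaches only the limit of the assay, > 20000 nM, and not a number. Compound 2 `O=c1[nH]cnc2c1c(-c1cccs1)cn2[C@@H]1O[C@H](CO)[C@@H](O)[C@H]1O` likewise gives only the assay limit, > 20000 nM. The step that the two limits leave unreadable from compound 2 to compound 3 is therefore unreadable, and compound 3 stands at the limit of > 20000 nM in this assay, at which 2 of the 3 values shown sit. Compound 1 `CN(C)c1ncnc2c1c(-c1ccsc1)cn2[C@@H]1O[C@H](CO)[C@@H](O)[C@H]1O`, which carries dimethylamino and thiophen-3-yl on its core, gives 1920 nM in this assay, but it differs from compound 3 in more than one place, so its number alone says nothing about a single change.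

Compound 4 `Nc1nc2c(c(-c3ccsc3)cn2[C@@H]2O[C@H](CO)[C@@H](O)[C@H]2O)c(=O)[nH]1` differs from compound 3 in one place: thiophen-3-yl in place of thiophen-2-yl on an aromatic carbon. No measured pair differs only in this way, so no measured step bears on it, and the one step that is shown cannot be read in size. Compound 4 is therefore expected to remain at the assay limit, with an estimate of 20000 nM and a range from 8000 nM to 50000 nM. The step of a number no higher from compound 3 to compound 4 (the limit leaves the size open) is estimated to be none beyond the scatter.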

Compound 4, half-maximal inhibitory concentration: > 20000 nM
Compound 4 ended at the assay's limit; the forecaster's own chance of this, stated with the estimate: 70%; the middle value sits exactly at the limit.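

In this assay compound 4 gives > 20000 nM, which is a limit and not a number; compound 3 also stands only at a limit, so the step between compound 3 and compound 4 cannot be read. The compounds shown leave open whether thiophen-3-yl and thiophen-2-yl differ at all in this assay.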